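Aryl swap on the 2-aminophenyl amide

The source may report more compounds than this note shows. Statements on the series, on what has been measured and on what is new or still open speak of the compounds shown alone.

In a functional assay on NCI-H661 cells (Homo sapiens) for antiproliferative activity, read by MTT assay, with a stated time of 72 h (a lower number here means a stronger inhibitor, a higher number a weaker inhibitor), compound 1 `Cc1ccc(-c2noc(CCCCCCC(=O)NO)n2)cc1` gives 15800 nM, compound 2 `O=C(CCCCCCc1nc(-c2cccnc2)no1)NO` gives 6020 nM and compound 3 `Cc1ccc(-c2noc(CCCCCCC(=O)Nc3ccccc3N)n2)cc1` gives 410 nM. Compound 3 has the lowest number of the three, and its gaps to both others lie beyond the scatter.

Compound 4 `Nc1ccccc1NC(=O)CCCCCCc1nc(-c2cccc([N+](=O)[O-])c2)no1` keeps the 2-aminophenyl amide of compound 3 and carries 3-nitrophenyl in place of 4-methylphenyl (3-nitrophenyl in place of 4-methylphenyl on an aromatic carbon).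

Among the measured compounds shown here, only one measured step changes the group at this place: a 2.6-fold lower number from compound 1 to compound 2 (0.42 log units; beyond the scatter), with pyridin-3-yl entering on the hydroxy form. The step of a 39-fold lower number from compound 1 to compound 3 (1.59 log units; beyond the scatter) is much larger, but it concerns the amide nitrogen, which does not change here. For the measured compounds named here, no measured compound carries 3-nitrophenyl, and no swap at this place has been measured on the 2-aminophenyl amide. In this assay a small step towards a lower number is therefore expected, possibly none beyond the scatter. The expected step is a 1.4-fold lower number from compound 3 to compound 4 (0.14 log units; within the scatter). For compound 4 the estimate is 300 nM, with an expected range of 100 nM to 900 nM.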

Compound 4, half-maximal inhibitory concentration: 7290 nM
Compound 4: the middle estimate sits 24-fold (1.39 log units) below what was measured; measured number outside the range, above it.
By their numbers in this assay, from the lowest: compound 3; then compounds 2 and 4 (each within the scatter of the next); then compound 1.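

In this assay the swap on the 2-aminophenyl amide gives an 18-fold higher number from compound 3 to compound 4 (1.25 log units; beyond the scatter) and so shows that the aryl group on this carbon, between two ring nitrogen atoms, can change the number strongly on this amide. This step runs the opposite way to a 2.6-fold lower number from compound 1 to compound 2 (0.42 log units; beyond the scatter) on the hydroxy form, yet the entering group and the amide form both differ, so the two steps do not give one rule for this position. Nothing measured here bears on the reason for the rise.

Still open, from the compounds shown here alone, is whether the rise follows the nitro group, its place on the phenyl ring, or the pairing with the 2-aminophenyl amide. Pyridin-3-yl, 4-nitrophenyl or 3-aminophenyl on the 2-aminophenyl amide, and 3-nitrophenyl on the hydroxy form, would separate these readings.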